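Chloro for trifluoromethyl on a urea-linked aryl group

This account rests on a few compounds, and the source may have more. Where it says the series, first, only, none or still open, it means among the compounds named here.

Compound 1 `O=C(Nc1cccc(-n2cc(-c3ccncc3)c(-c3cc(O)cc(Cl)c3)n2)c1)Nc1ccc(Cl)c(C(F)(F)F)c1`: 97%
Compound 2 `O=C(Nc1cccc(-n2cc(-c3ccncc3)c(-c3cc(O)cc(Cl)c3)n2)c1)Nc1ccc(Cl)c(Cl)c1`: 108%
Compound 3 `COc1cc(Cl)cc(-c2nn(-c3cccc(NC(=O)Nc4ccc(Cl)c(C(F)(F)F)c4)c3)cc2-c2ccncc2)c1`: 98%

Of the compounds shown here, three sharing one core have been measured in a functional assay on SK-MEL-28 cells (Homo sapiens) for inhibition, read by sulforhodamine B assay, with a stated time of 48 h, tested at 0.01 uM; a lower number here means a stronger effect, a higher number a weaker effect of the compound at the concentration tested. Compound 1 gives 97%, compound 2 gives 108%, and compound 3 gives 98%. Among these three numbers compound 3 stands second highest; it is nearest to compound 1, and its gap to compound 2 lies within the scatter, as does its gap to compound 1.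

Compound 4 `COc1cc(Cl)cc(-c2nn(-c3cccc(NC(=O)Nc4ccc(Cl)c(Cl)c4)c3)cc2-c2ccncc2)c1` is not yet measured. It differs from compound 3 in one place: chloro in place of trifluoromethyl on an aromatic carbon. The same exchange has been seen once already, on the pair that differ in exactly the same way: a number 11 percentage points higher from compound 1 to compound 2 (beyond the scatter). That step was modest but beyond the scatter, and compound 4 is therefore expected to lie a little higher in this assay than compound 3, by a step estimated as a number 10 percentage points higher from compound 3 to compound 4 (within the scatter). The estimate for compound 4 is 108%, with a range from 95% to 121%.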

Compound 4, a percentage reported as activity, at one concentration (the size of the read-out at that concentration, not a potency): 101%
The estimate for compound 4 lay 7 percentage points above the measured number, and the stated range covers the measured number.
By their numbers in this assay, from the lowest: compounds 1, 3, 4 and 2 (each within the scatter of the next, the first and the last beyond it).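

In this assay, for the compounds shown here, chloro in place of trifluoromethyl now reads on the core that carries the methyl on the oxygen, as a number 3 percentage points higher from compound 3 to compound 4 (within the scatter), so the one earlier step beyond the scatter finds no counterpart beyond it on this second core, though the two readings do not differ beyond what two such steps allow: the same change on two cores in this assay, a number 11 percentage points higher (beyond the scatter) from compound 1 to compound 2 and a number 3 percentage points higher (within the scatter) from compound 3 to compound 4, 8 percentage points apart, within the scatter of two such steps. The methyl on the oxygen can now also be read with 3,4-dichlorophenyl in place of 4-chloro-3-(trifluoromethyl)phenyl, as a number 7 percentage points lower from compound 2 to compound 4 (within the scatter), and it stays within the scatter on both cores: the same change on two cores in this assay, a number 1 percentage points higher (within the scatter) from compound 1 to compound 3 and a number 7 percentage points lower (within the scatter) from compound 2 to compound 4, 8 percentage points apart, within the scatter of two such steps. Neither change therefore shows a repeatable shift of the read-out across these four compounds.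

From the compounds shown here alone, whether a nitrile or an amine in this place would read differently remains open. So does how these compounds behave at any other concentration.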